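This account rests on a few compounds, and the source may have more. Where it says the series, first, only, none or still open, it means among the compounds named here.

In a functional assay on MDA-MB-231 cells for antagonist activity at C-X-C chemokine receptor type 4 (Homo sapiens), tested at 100 nM (on this read-out lower numbers stand for a weaker effect and higher numbers for a stronger effect at the one concentration tested), compound 1 `c1ccc(NCc2ccc(CNc3ncccn3)cc2)cc1` gives 100%, compound 2 `c1ccc(NCc2ccc(CNc3ncccn3)cc2)nc1` gives 64%, and compound 3 `Fc1ccc(NCc2ccc(CNc3ncccn3)cc2)nc1` gives 78%. Compound 3 stands second highest of the three numbers: its nearest neighbour is compound 2, and the change a number 14 percentage points higher from compound 2 to compound 3 (beyond the scatter) lies beyond the scatter, while the change a number 22 percentage points lower from compound 1 to compound 3 (beyond the scatter) puts compound 1 furthest away. The change a number 36 percentage points lower from compound 1 to compound 2 (beyond the scatter) is the largest single step among the measured compounds.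

Compound 4 `Clc1ccc(NCc2ccc(CNc3ncccn3)cc2)nc1` is not yet measured. It differs from compound 3 by chloro in place of fluoro on an aromatic carbon, on an aromatic carbon of a six-membered aromatic ring with one nitrogen, two atoms from the ring nitrogen.

Within the data shown here, only one measured step touches that position: the change a number 14 percentage points higher from compound 2 to compound 3 (beyond the scatter), where a halogen entered in place of hydrogen and the number rose by a modest amount. Among the measured compounds shown here, no measured pair shows chloro against fluoro, so the comparison rests on that single step alone. The expectation is therefore that compound 4 keeps a number close to compound 3, with a step of a number 4 percentage points higher from compound 3 to compound 4 (within the scatter) that is expected to stay within the scatter, perhaps leaning slightly upward. Compound 4 is estimated at 82%, within a range from 66% to 96%.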

Compound 4, a percentage reported as inhibition, at one concentration (the size of the read-out at that concentration, not a potency): 100%
Compound 4: middle estimate off by 18 percentage points, on the low side; measured number above the stated range.
By their numbers in this assay, from the lowest: compound 2; then compound 3; then compounds 1 and 4 (each within the scatter of the next).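

The earlier compounds shown here showed only that a halogen at this position raised the number over hydrogen; compound 4 shows that the identity of the halogen matters as well, with a number 22 percentage points higher from compound 3 to compound 4 (beyond the scatter) in this assay and a number 36 percentage points higher from compound 2 to compound 4 (beyond the scatter). The step of no change at the digits printed from compound 1 to compound 4 (within the scatter) also shows that, among these compounds, swapping phenyl for a pyridine ring on the amine nitrogen need not lower the number, since the 5-chloropyridin-2-yl group leaves it level with phenyl, whereas the pyridin-2-yl and 5-fluoropyridin-2-yl groups of compound 2 and compound 3 stay clearly lower. Nothing available here explains why chloro and fluoro part at this position.

The compounds shown leave open whether this gain extends to other groups at the same place, such as bromo, methyl, methoxy or nitrile, or whether it is particular to chloro. They also leave open how compound 1 and compound 4 would compare across a range of concentrations, as a single concentration gives the size of the effect and not a potency.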